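Extending the enamide chain on a thienopyrimidine series

A few compounds are considered here, and "the series" means these few. Any claim that something is new, unique, unknown or untested is made for them only; others in the source may bear on it.

Measured compounds:
- compound 1 `C=CC(=O)Nc1cccc(Oc2nc(Nc3cccc(OC)c3)nc3ccsc23)c1`, 4340 nM
- compound 2 `C/C=C/C(=O)Nc1cccc(Oc2nc(Nc3cccc(OC)c3)nc3ccsc23)c1`, 10500 nM

Compound 2 sits at the higher of the two numbers obtained in a functional assay on A549 cells (Homo sapiens) for inhibition, read by MTT assay, with a stated time of 72 h; a lower number here means a stronger inhibitor, a higher number a weaker inhibitor. Among the measured compounds shown here, its nearest neighbour is compound 1, and the single measured step, a 2.4-fold higher number from compound 1 to compound 2 (0.38 log units; beyond the scatter), reaches beyond the scatter and goes in the direction of weaker inhibition.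

Compound 3 `COc1cccc(Nc2nc(Oc3cccc(NC(=O)C=C(C)C)c3)c3sccc3n2)c1` is not yet measured in this assay. It differs from compound 2 by one change: 2-methylprop-1-en-1-yl in place of prop-1-en-1-yl on a carbonyl carbon. For the measured compounds named here, the only measured step that bears on this change is a 2.4-fold higher number from compound 1 to compound 2 (0.38 log units; beyond the scatter), which lengthened the same chain by one carbon and gave a modest rise in the number. Compound 3 adds one more carbon to that chain, so a further rise of comparable size is the expectation, with a flat result within the scatter also plausible.

For compound 3, the estimated step is a 1.9-fold higher number from compound 2 to compound 3 (0.28 log units; within the scatter). Compound 3 is therefore expected to give about 20000 nM in this assay, with a likely range from 8000 nM to 50000 nM.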

Compound 3, half-maximal inhibitory concentration: 27700 nM
Compound 3: the middle estimate sits 1.4-fold (0.14 log units) below what was measured; the range from low to high includes it.
By their numbers in this assay, from the lowest: compound 1; then compound 2; then compound 3.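

In this assay the change on the carbonyl carbon gives a second rise, a 2.6-fold higher number from compound 2 to compound 3 (0.42 log units; beyond the scatter), so the number does not level off when 2-methylprop-1-en-1-yl takes the place of prop-1-en-1-yl. Vinyl, prop-1-en-1-yl and 2-methylprop-1-en-1-yl now form an ordered series at this one place, spanning a 6.4-fold higher number from compound 1 to compound 3 (0.80 log units; beyond the scatter), and none of the three compounds goes against the order in which more carbon on this chain comes with a higher number and weaker inhibition. No measurement is available that bears on what lies behind this order, and the series records its direction only.

The compounds shown leave open whether an amine-bearing chain, or an ethyl group in place of vinyl, on the same carbonyl carbon would continue this order or break it. They also leave open whether any group at this place would give a lower number than vinyl, and whether the same order would hold with other groups on the shared core.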